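Cyclopropyl to Propyl: Expected Cytotoxicity for Compound 4

The source may hold more compounds than are shown below. What is called first, only, known or untested is meant among the compounds shown, and "the series" means these compounds.

Compound 1 `COc1nc2ccc(Br)cc2cc1C(c1ccccc1)n1cc(C2CC2)nn1`: 8.22%
Compound 2 `CCCCCCc1cn(C(c2ccccc2)c2cc3cc(Br)ccc3nc2OC)nn1`: -3.17%
Compound 3 `COc1nc2ccc(Br)cc2cc1C(c1ccccc1)n1cc(-c2ccccc2)nn1`: 8.25%

In an ADME assay on HEK293 cells (Homo sapiens) for cytotoxicity, read by sulforhodamine B assay, with a stated time of 48 h, tested at 10 uM (on this read-out higher numbers stand for more inhibition at the one concentration tested (going by the name of the read-out) and lower numbers for less inhibition), compound 1 stands second highest of the three numbers; compound 3 lies within the scatter of it, while compound 2 is lower beyond the scatter. Compound 4 `CCCc1cn(C(c2ccccc2)c2cc3cc(Br)ccc3nc2OC)nn1` has not yet been measured. It differs from compound 1 by propyl in place of cyclopropyl on an aromatic carbon. Among the measured compounds shown here, two measured steps bear on this change: a number 11.4 percentage points lower from compound 1 to compound 2 (beyond the scatter), and a number 0 percentage points higher from compound 1 to compound 3 (within the scatter). An open hexyl chain thus came with a modest drop, a phenyl with no change. Propyl is an open chain shorter than hexyl, so a small drop is expected, probably within the scatter: a number 5.2 percentage points lower from compound 1 to compound 4 (within the scatter) is the expected step. Compound 4 is therefore estimated at 3%, with a range from -8% to 14%.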

Compound 4, a percentage reported as inhibition, at one concentration (the size of the read-out at that concentration, not a potency): 0.85%
Compound 4: middle estimate off by 2.2 percentage points, on the high side, and the stated range covers the measured number.
By their numbers in this assay, from the lowest: compounds 2, 4, 1 and 3 (each within the scatter of the next, the first and the last beyond it).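

In this assay, opening the cyclopropyl ring into a propyl chain with the same count of carbons gives a number 7.4 percentage points lower from compound 1 to compound 4 (within the scatter), replacing phenyl with propyl gives a number 7.4 percentage points lower from compound 3 to compound 4 (within the scatter), and shortening hexyl to propyl gives a number 4 percentage points higher from compound 2 to compound 4 (within the scatter). Propyl therefore lies within the scatter of all three other groups at this position, so the loss of the ring cannot be told apart from no change here. Nothing available explains these differences.

As far as these compounds go, what an amine or a carboxylic acid would do at this position stays open. So does the effect of a chain longer than hexyl.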